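A few compounds are considered here, and "the series" means these few. Any claim that something is new, unique, unknown or untested is made for them only; others in the source may bear on it.

Measured so far in a physicochemical assay for solubility, at pH 7.4; on this read-out higher numbers stand for higher solubility and lower numbers for lower solubility
compound 1 `Cc1cc(NC(=O)Nc2ccccc2OC(F)(F)F)c2ccccc2n1` gives 4600 nM
compound 2 `Cc1cc(NC(=O)Nc2ccccc2N)c2ccccc2n1` gives 51800 nM
compound 3 `Cc1cc(NC(=O)Nc2cccc(F)c2)c2ccccc2n1` gives 100 nM

Compound 2 with 51800 nM holds the highest of the three numbers, with compound 1 the nearest and compound 3 the furthest. Compound 4 `Cc1cc(NC(=O)Nc2ccccc2C(N)=O)c2ccccc2n1` is still unmeasured. It carries carbamoyl in place of amino on an aromatic carbon, ortho to a large group, and its difference from compound 2 counts as carbamoyl in place of amino on an aromatic carbon in full.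

Among the measured compounds shown here, two measured steps bear on this change, and both are large. The closer one is an 11-fold higher number from compound 1 to compound 2 (1.05 log units; beyond the scatter) and concerns the same amino group. The other is a 520-fold lower number from compound 2 to compound 3 (2.71 log units; beyond the scatter) and is a wider change, 3-fluorophenyl in place of 2-aminophenyl on an amide-type nitrogen. For the measured compounds named here, no measured compound carries carbamoyl, so the size remains uncertain.

Since compound 1 with 4600 nM and compound 3 with 100 nM both lie lower than compound 2, a moderate move to a lower number is expected. The estimated change is a 4.3-fold lower number from compound 2 to compound 4 (0.64 log units; beyond the scatter) in this assay and would be smaller than either measured step. For compound 4 the estimate is 12000 nM with an expected range from 2500 nM to 50000 nM in this read-out.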

Compound 4, solubility: 200 nM
Beside the measured number, compound 4's estimate is 60-fold (1.78 log units) above it; the measured number lies below the stated range.
By their numbers in this assay, from the lowest: compounds 3 and 4 (each within the scatter of the next); then compound 1; then compound 2.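

In this assay, carbamoyl in place of amino on an aromatic carbon, ortho to a large group, brings a 260-fold lower number from compound 2 to compound 4 (2.41 log units; beyond the scatter), which shows that this place responds strongly to this exchange even though the amino and carbamoyl groups have equal counts of hydrogen-bond donors and acceptors. Carbamoyl in place of trifluoromethoxy at the same place brings a 23-fold lower number from compound 1 to compound 4 (1.36 log units; beyond the scatter). The three groups at this place therefore run from amino through trifluoromethoxy to carbamoyl, from the highest number to the lowest, with every step beyond the scatter.

Nothing measured here accounts for the size of these steps. Going by these compounds, whether a carboxylic acid, a methyl ester or a longer chain at this place would stand nearer to compound 2 or to compound 4 remains open.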